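Phenyl for propargyl on the ring oxygen

The source may report more compounds than this note shows. Statements on the series, on what has been measured and on what is new or still open speak of the compounds shown alone.

Within the data shown here, in a functional assay on A549 cells (Homo sapiens) for inhibition, read by sulforhodamine B assay, with a stated time of 48 h, tested at 50 uM (a higher number here means more inhibition of growth at the concentration tested, a lower number less inhibition of growth), only two compounds have been measured so far. Compound 1 `COc1cc2c(cc1CC=C(C)C)C(=O)C[C@@H](c1ccc(Oc3cccc([N+](=O)[O-])c3)cc1)O2` gives 37%, and compound 2 `C#CCOc1ccc([C@@H]2CC(=O)c3cc(CC=C(C)C)c(OC)cc3O2)cc1` gives 53%, the higher of the two numbers. The next compound, compound 3 `COc1cc2c(cc1CC=C(C)C)C(=O)C[C@@H](c1ccc(Oc3ccccc3)cc1)O2`, keeps the core of compound 2 and changes one group: phenyl in place of propargyl on an oxygen on an aromatic ring.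

Among the measured compounds shown here, only one measured step bears on this change. It is a number 16 percentage points higher from compound 1 to compound 2 (beyond the scatter), and it came from putting propargyl in place of 3-nitrophenyl at that same oxygen. Read in reverse, this step suggests that replacing propargyl with an aromatic ring may lower the number. However, compound 3 carries phenyl rather than 3-nitrophenyl, and a single step is thin evidence, so the size of any drop remains uncertain. The expected change is a number 13 percentage points lower from compound 2 to compound 3 (beyond the scatter), a fall of similar or slightly smaller size. For compound 3, the estimated value is 40%, with an expected range from 26% to 54%.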

Compound 3, percent growth inhibition at one concentration: 46%
Compound 3: middle estimate off by 6 percentage points, on the low side; the measured number falls inside the stated range.
By their numbers in this assay, from the lowest: compounds 1, 3 and 2 (each within the scatter of the next, the first and the last beyond it).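

Phenyl in place of propargyl on the ring oxygen gives a number 7 percentage points lower from compound 2 to compound 3 (within the scatter) in this assay, so this measurement does not separate the phenoxy compound from the propargyloxy one. Hydrogen in place of nitro on the aromatic ring gives a number 9 percentage points higher from compound 1 to compound 3 (within the scatter), so removing the nitro group also produces no difference that can be distinguished from ordinary assay variation. Compound 3 therefore sits within the scatter of both neighbours, even though a number 16 percentage points higher from compound 1 to compound 2 (beyond the scatter) lies beyond it, which means the earlier step cannot be pinned on the nitro group or on the ring alone, and no measurement here offers an explanation for these numbers.

Still open, on these data alone, is whether an amine or a carboxylic acid in place of the nitro group on the phenyl ring, or a longer chain in place of propargyl on the oxygen, would shift growth inhibition beyond the scatter. All three numbers also come from a single tested concentration, so they do not show how the inhibition of each compound changes with dose.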